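Adding a Second Chloro Group to the Best Compound

A few compounds are considered here, and "the series" means these few. Any claim that something is new, unique, unknown or untested is made for them only; others in the source may bear on it.

All three measured compounds share one core and differ only in the group on a saturated ring carbon. Compound 1 `COc1ccc([C@H]2CC(c3cc4ccccc4oc3=O)=NN2c2ccccc2)cc1` carries a 4-methoxyphenyl there, compound 2 `O=c1oc2ccccc2cc1C1=NN(c2ccccc2)[C@@H](/C=C/c2ccccc2)C1` a 2-phenylethenyl, and compound 3 `O=c1oc2ccccc2cc1C1=NN(c2ccccc2)[C@@H](c2ccc(Cl)cc2)C1` a 4-chlorophenyl. In a functional assay on the whole organism (strain albino) for inhibition, with Rattus norvegicus as the target, read by paw edema, with stated times of 1 h and 4 h, at a dose of 200 mg/kg by the oral route (a higher number here means more inhibition at the dose given (going by the name of the read-out), a lower number less inhibition), compound 1 gives 36.2%, compound 2 gives 42.5%, and compound 3 gives 64.7%. Compound 3 stands highest of the three, with its steps to both others beyond the scatter: a number 22.2 percentage points higher from compound 2 to compound 3 (beyond the scatter) and a number 28.5 percentage points higher from compound 1 to compound 3 (beyond the scatter). The remaining step, a number 6.3 percentage points higher from compound 1 to compound 2 (within the scatter), lies within the scatter.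

Compound 4 `O=c1oc2ccccc2cc1C1=NN(c2ccccc2)[C@@H](c2ccc(Cl)cc2Cl)C1` differs from compound 3 by a single change, (chloro in place of hydrogen on an aromatic carbon). Going by the values given here, only one measured step involves a chloro group at all, namely a number 28.5 percentage points higher from compound 1 to compound 3 (beyond the scatter), a modest rise, but there chloro replaced methoxy rather than hydrogen, and no measured pair shows the effect of a second chloro on the same ring. With the chloro-bearing compound 3 already highest, as a number 28.5 percentage points higher from compound 1 to compound 3 (beyond the scatter) shows, a small rise or no change beyond the scatter is expected, so the step of a number 2.3 percentage points higher from compound 3 to compound 4 (within the scatter) is estimated to be small. Compound 4 is therefore expected to give about 67% in this assay, within a range from 52% to 80%.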

Compound 4, a percentage reported as inhibition, in the whole organism at one dose (the size of the read-out at that dose, not a potency): 67.5%
Compound 4: middle estimate off by 0.5 percentage points, on the low side; measured number inside the range.
By their numbers in this assay, from the lowest: compounds 1 and 2 (each within the scatter of the next); then compounds 3 and 4 (each within the scatter of the next).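

In this assay, the change from 4-chlorophenyl to 2,4-dichlorophenyl, which places a chloro ortho to a large group, gives a step of a number 2.8 percentage points higher from compound 3 to compound 4 (within the scatter), so a second chloro on this ring leaves the read-out unchanged as far as this assay can tell. The new compound also keeps its distance from the two compounds without chloro, with steps of a number 25 percentage points higher from compound 2 to compound 4 (beyond the scatter) and a number 31.3 percentage points higher from compound 1 to compound 4 (beyond the scatter), so the 2,4-dichlorophenyl and 4-chlorophenyl groups together stand apart from the 2-phenylethenyl and 4-methoxyphenyl groups at this saturated ring carbon. Nothing at hand explains why the second chloro makes so little difference here.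

The compounds shown leave open whether chloro itself matters on this ring, since a plain phenyl, or a phenyl carrying a fluoro or a nitro group, would be needed to tell. They also leave open whether compound 3 and compound 4 would stay together at a lower oral dose, because a single dose shows the size of the read-out and not a potency.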